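Adding a Fluorine to the Phenyl Ring of Compound 2

The source may report more compounds than this note shows. Statements on the series, on what has been measured and on what is new or still open speak of the compounds shown alone.

Measured so far:
compound 1, `CC1CC(=O)c2s/c(=N/c3ccccc3)oc2C1`: 2720 nM
compound 2, `CC(C)C1CC(=O)c2s/c(=N/c3ccccc3)oc2C1`: 2280 nM

In a functional assay on NCI-H23 cells (Homo sapiens) for antiproliferative activity, read by sulforhodamine B assay (a lower number here means a stronger inhibitor of growth, a higher number a weaker inhibitor of growth), compound 1 gives 2720 nM, and compound 2 gives 2280 nM. Within the data shown here, the two numbers lie within the scatter of each other, so neither compound can be called the stronger growth inhibitor; the only measured step, a 1.2-fold lower number from compound 1 to compound 2 (0.08 log units; within the scatter), shows that replacing methyl by isopropyl on the saturated ring changed little.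

Compound 3, `CC(C)C1CC(=O)c2s/c(=N/c3ccc(F)cc3)oc2C1`, keeps the isopropyl of compound 2 and differs from it only in fluoro in place of hydrogen on an aromatic carbon. Among the measured compounds shown here, no measured step touches the phenyl ring, so nothing here speaks directly to this change. With a single small atom entering and no evidence of a shift, compound 3 is expected to stay close to compound 2, with an estimated step of a 1.1-fold lower number from compound 2 to compound 3 (0.06 log units; within the scatter) and an expected value of 2000 nM (range 800 nM to 5000 nM).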

Compound 3, concentration for 50% growth inhibition: 3650 nM
For compound 3 the middle estimate is 1.8-fold (0.26 log units) below the measured one, within the range that was stated.
By their numbers in this assay, from the lowest: compounds 2, 1 and 3 (each within the scatter of the next).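

In this assay, among these compounds, the phenyl ring is tested for the first time, and the change from phenyl to 4-fluorophenyl gives a 1.6-fold higher number from compound 2 to compound 3 (0.20 log units; within the scatter). Fluoro and hydrogen on this aromatic carbon, para to a large group, therefore cannot be told apart by this measurement. Together with the earlier swap of methyl for isopropyl, this means that neither of the two places varied so far has moved the number beyond the scatter, and nothing available here offers an explanation for the small difference seen.

The compounds shown leave open whether a different group at this carbon, such as an amine or a methoxy group, would move the number beyond the scatter. They also leave open what fluoro on another ring carbon, or a longer chain in place of the isopropyl, would do.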